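This account rests on a few compounds, and the source may have more. Where it says the series, first, only, none or still open, it means among the compounds named here.

Working notes on the series.

Compound 1 `CCC(C)c1cc(/C=C/C(=O)c2ccc(Cl)cc2)cc2cc(C(C)=O)c(=O)oc12` and compound 2 `CCOC(=O)c1cc2cc(/C=C/C(=O)c3ccccc3)cc(C(C)CC)c2oc1=O` are the two members without a number in a functional assay on NIH3T3 cells (Mus musculus) for cytotoxicity, read by sulforhodamine B assay, with a stated time of 48 h; a lower number here means a stronger inhibitor, a higher number a weaker inhibitor: compound 1 is recorded as "not active" (no number reported), and compound 2 likewise as "not active" (no number reported). Among the compounds with values here, compound 3 `CCOC(=O)c1cc2cc(/C=C/C(=O)c3ccc(Cl)cc3)cc(C(C)CC)c2oc1=O` is the only member with a measured value in this assay, giving 38400 nM. It therefore stands alone on the numbers shown; the two further entries carry no value against which it could be ranked, and no step between measured compounds can be drawn.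

Compound 4 `CCOC(=O)c1cc2cc(/C=C/C(=O)c3ccc(C)cc3)cc(C(C)CC)c2oc1=O` is the next member to be measured in this assay. It differs from compound 3 in one place, (methyl in place of chloro on an aromatic carbon), so the (4-chlorophenyl)carbonyl of compound 3 becomes a (4-methylphenyl)carbonyl in compound 4. With no measured step of this kind in the series, nothing here points to a change beyond the scatter; the expectation is a step of about a 1.3-fold higher number from compound 3 to compound 4 (0.11 log units; within the scatter), if anything a slight weakening. Compound 4 is accordingly expected to give about 50000 nM in this assay, within a range of 20000 nM to 150000 nM, with a real chance that only a limit is reported.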

Compound 4, half-maximal inhibitory concentration: "not active" (no number reported)
For compound 4 the study gives words and no number; no gap can be computed for the estimate.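

In this assay, within the data shown here, compound 4 is recorded as "not active" (no number reported) and carries no number, so no step from compound 3 to compound 4 can be read. The compounds shown leave open how far 4-chlorophenyl to 4-methylphenyl moves the read-out on the shared core. Nothing measured here offers an explanation for this result.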